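Replacing the Amino Group: What to Expect for Compound 3

The source may hold more compounds than are shown below. What is called first, only, known or untested is meant among the compounds shown, and "the series" means these compounds.

Compound 1 `Cc1cc(C(=O)Nc2ccc(-c3ccccc3S(N)(=O)=O)cc2)n(-c2cccc(N)c2)n1` was tested in an assay on isolated protein for inhibition of Trypsin (Homo sapiens) (on this read-out lower numbers stand for stronger inhibition and higher numbers for weaker inhibition), and gives only a limit of the assay there, > 1600 nM. Its companion compound 2 `Cc1cc(C(=O)Nc2ccc(-c3ccccc3S(N)(=O)=O)cc2)n(-c2cccc(C(N)=O)c2)n1` likewise returns only a limit in this assay, > 1600 nM. For the measured compounds named here, the one step between them, a step that the two limits leave unreadable from compound 1 to compound 2, therefore cannot be read, and the sole evidence on the measured pairs is the limit of > 1600 nM in this assay, at which 2 of the 2 values shown sit.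

The unmeasured compound 3 `Cc1cc(C(=O)Nc2ccc(-c3ccccc3S(N)(=O)=O)cc2)n(-c2cccc(C(=N)NO)c2)n1` differs from compound 1 by a group of 4 heavy atoms (1 carbon, 2 nitrogen, 1 oxygen; no ring) in place of one nitrogen atom, on an aromatic carbon; in words, a group of 4 heavy atoms (1 carbon, 2 nitrogen, 1 oxygen; no ring) in place of one nitrogen atom, on an aromatic carbon. Going by the values given here, no measured step bears on this change with a readable size: the only neighbouring step, from an amino to a carbamoyl group on that same ring, is hidden by the two limits. Among the compounds with values here, with no step of readable size in this assay, there is no basis to expect a gain beyond the scatter, and the estimate for compound 3 stays near the limit, corresponding to a step that the limit leaves unreadable from compound 1 to compound 3. Compound 3 is thus estimated at 3000 nM, with a range from 800 nM to 20000 nM.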

Compound 3, inhibition constant: > 1600 nM
Compound 3: only a limit was reported (the forecaster's own chance of this, stated with the estimate: 75%); the middle value does not contradict the limit.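

In this assay compound 3 gives > 1600 nM, which is a limit of the assay. No new step can be read among compound 1, compound 2 and compound 3, because all of them rest on the same limit: the limit of > 1600 nM in this assay, at which 3 of the 3 values shown sit.

The compounds shown leave open whether the amino, carbamoyl and compound 3 groups differ at all in this assay.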